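The source may hold more compounds than are shown below. What is called first, only, known or untested is meant among the compounds shown, and "the series" means these compounds.

Measured so far:
compound 1 `O=C1C=C(Nc2ccc(Br)cc2)C(=O)c2c1nc1n2[C@H]2OC[C@@H](O)[C@H]2OC1`, 1010 nM
compound 2 `COc1cccc(NC2=CC(=O)c3c(nc4n3[C@H]3OC[C@@H](O)[C@H]3OC4)C2=O)c1`, 1790 nM

In a functional assay on MGC-803 cells (Homo sapiens) for inhibition, read by sulforhodamine B assay (a higher number here means a weaker inhibitor, a lower number a stronger inhibitor), compound 1 gives 1010 nM and stands lowest of the two numbers shown; compound 2, at 1790 nM, lies within the scatter of it, so no order between the two can be read. For the measured compounds named here, no step between measured compounds that differ in one place is available.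

Compound 3 `O=C1C=C(Nc2cccc(Cl)c2)C(=O)c2c1nc1n2[C@H]2OC[C@@H](O)[C@H]2OC1` differs from compound 1 by 3-chlorophenyl in place of 4-bromophenyl on an amine nitrogen. Nothing measured bears directly on this change. The two measured compounds carry different groups on the same amine nitrogen and still sit within the scatter of each other, which gives no ground to expect a large move from a further swap of this kind. The expectation for compound 3 is therefore a step of a 1.5-fold higher number from compound 1 to compound 3 (0.17 log units; within the scatter) that stays within the scatter, if anything toward a somewhat higher number. Compound 3 is estimated at 1500 nM, with a range from 700 nM to 3200 nM.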

Compound 3, half-maximal inhibitory concentration: 1770 nM
Compound 3: the middle estimate sits 1.2-fold (0.07 log units) below what was measured, within the range that was stated.
By their numbers in this assay, from the lowest: compounds 1, 3 and 2 (each within the scatter of the next).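

In this assay, for the compounds shown here, the first one-place step, 3-chlorophenyl in place of 4-bromophenyl on the amine nitrogen, reads a 1.8-fold higher number from compound 1 to compound 3 (0.24 log units; within the scatter) and lies within the scatter. This position therefore tolerates a change of both the halogen and its place on the phenyl ring without a step that can be read beyond the scatter, although the two changes cannot be separated here. No measurement at hand bears on the reason for this result.

Open is whether 4-chlorophenyl or 3-bromophenyl would behave like the compounds shown, which would separate the halogen from its place. Also open, on these data alone, is how this amine nitrogen responds to a group of another kind, such as a carboxylic acid on the phenyl ring or a longer alkyl chain in place of the ring.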